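A few compounds are considered here, and "the series" means these few. Any claim that something is new, unique, unknown or untested is made for them only; others in the source may bear on it.

In an ADME assay on EA.hy 926 cells (Homo sapiens) for inhibition, read by MTT assay, with a stated time of 72 h (on this read-out lower numbers stand for stronger inhibition and higher numbers for weaker inhibition), compound 1 `CC(C)CNC(=C\C(=O)/C=C/c1ccc(O)cc1)/C=C/c1ccc(O)cc1` gives > 25000 nM, which is a limit of the assay and not a number. Compound 2 `COc1cc(/C=C/C(=O)CC(=O)/C=C/c2ccc(OC(C)=O)c(OC)c2)ccc1OC(C)=O` gives > 25000 nM, which is also a limit. Compound 3 `CCC(C)NC(=C\C(=O)/C=C/c1ccc(O)cc1)/C=C/c1ccc(O)cc1` has the same atoms as compound 1, joined differently: sec-butyl in place of isobutyl on an amine nitrogen, with sec-butyl in place of isobutyl on an amine nitrogen. No measured pair sizes this change in this assay, so the expected step, a number no higher from compound 1 to compound 3 (the limit leaves the size open), is estimated to lie within the usual scatter, with no direction favoured. For compound 3, the expected value is 25000 nM, with an estimated range from 12000 nM to 50000 nM.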

Compound 3, half-maximal inhibitory concentration: 22000 nM
Compound 3: middle estimate off by 1.1-fold (0.06 log units), on the high side, and the stated range covers the measured number.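

In this assay, going by these compounds alone, sec-butyl in place of isobutyl on an amine nitrogen yields the only number among the values shown rather than a limit, and the change reads as an at least 1.1-fold lower number from compound 1 to compound 3 (0.05 log units; that floor lies within the scatter). As far as these compounds go, the value of compound 1 is a limit of the assay and not a number, so this step has only a floor and its true size stays open: the limit of > 25000 nM in this assay, at which 2 of the 3 values shown sit. The compounds shown leave open whether a longer chain, a cyclohexyl group or a benzyl group on this nitrogen would give a lower number.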